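The source may hold more compounds than are shown below. What is called first, only, known or untested is meant among the compounds shown, and "the series" means these compounds.

In a functional assay on HCT-8 cells (Homo sapiens) for antiproliferative activity, read by MTT assay, with a stated time of 48 h (a higher number here means a weaker inhibitor, a lower number a stronger inhibitor), compound 1 `COc1ccc(C(=O)c2ccc3c(c2)C=CC(C)(C)O3)c(NC(=O)CN(C)C)c1` gives 2420 nM, compound 3 `C=C(c1ccc(OC)cc1NC(=O)CN(C)C)c1ccc(OC)c2c1OC(C)(C)C=C2` gives 690 nM and compound 2 `C=C(c1cc(OC)c(OC)c(OC)c1)c1ccc(OC)cc1NC(=O)CN` gives 60 nM. Compound 2 therefore holds the lowest number of the three, and its gaps to both of the others lie beyond the scatter. Compound 4 `C=C(c1cc(OC)c(OC)c(OC)c1)c1ccc(OC)cc1NC(=O)CN(C)C` has not yet been measured. It differs from compound 2 in one place, with dimethylamino in place of amino on a saturated chain carbon bound to a carbonyl carbon. Within the data shown here, no measured pair shows this change alone, so its size cannot be read directly. Compound 3 carries the dimethylamino group but also differs elsewhere, and it gives 690 nM. That value offers only a loose guide, and a modest rise in the number in this assay is expected, not a large one. The expected change is a 1.7-fold higher number from compound 2 to compound 4 (0.22 log units; within the scatter), which may not clear the scatter. The estimated value for compound 4 is 100 nM, with an expected range from 25 nM to 400 nM.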

Compound 4, half-maximal inhibitory concentration: 340 nM
The estimate for compound 4 lay 3.4-fold (0.53 log units) below the measured number; low and high end bracket the measured number.
By their numbers in this assay, from the lowest: compound 2; then compound 4; then compound 3; then compound 1.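

In this assay, the change to dimethylamino in place of amino on a saturated chain carbon bound to a carbonyl carbon now has a size of its own: a 5.7-fold higher number from compound 2 to compound 4 (0.75 log units; beyond the scatter). Among these compounds, until now the dimethylamino group had appeared only in compounds that also differed elsewhere, so this pair is the first to show that this position responds to the change alone, with the amino form giving the lower number. No measured evidence bears on why the number rises.

The compounds shown leave open how methylamino or a ring amine such as pyrrolidine would stand at this place. They also leave open whether the same change would give a step of similar size on the cores of compound 1 and compound 3.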